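A New Group on the Sulfonyl Sulfur

The source may hold more compounds than are shown below. What is called first, only, known or untested is meant among the compounds shown, and "the series" means these compounds.

Of the compounds shown here, two sharing one core have been measured in a functional assay on K562 cells (Homo sapiens) for inhibition, read by trypan blue exclusion, with a stated time of 72 h; on this read-out higher numbers stand for weaker inhibition and lower numbers for stronger inhibition. There, compound 1 `Cn1c(=O)c(S(=O)(=O)Cc2ccc(F)cc2F)cc2cnc(Nc3ccc4[nH]ccc4c3)nc21` gives 1000 nM, while compound 2 `Cn1c(=O)c(S(=O)(=O)c2ccc(Cl)cc2)cc2cnc(Nc3ccc4[nH]ccc4c3)nc21` gives 100 nM, the lower of the two numbers. Compound 3 `Cn1c(=O)c(S(=O)(=O)Nc2ccc(F)cc2)cc2cnc(Nc3ccc4[nH]ccc4c3)nc21` keeps the shared core and differs from compound 2 in one place: (4-fluorophenyl)amino in place of 4-chlorophenyl on a sulfonyl sulfur. In words, (4-fluorophenyl)amino stands in place of 4-chlorophenyl on a sulfonyl sulfur.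

For the measured compounds named here, only one measured step bears on this change, and it falls at the same place: a 10-fold lower number from compound 1 to compound 2 (1.00 log units; beyond the scatter), with 4-chlorophenyl in place of 2,4-difluorobenzyl. That step shows that this assay can respond to a change on this sulfur. Going by the values given here, it is a single step, however, and no measured compound carries an amino group there, so the new change has no direct precedent. A modest move toward a higher number is therefore expected, smaller than the measured step. The expected step is a 2.0-fold higher number from compound 2 to compound 3 (0.30 log units; within the scatter). The estimate for compound 3 is 200 nM, with an expected range from 50 nM to 1000 nM.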

Compound 3, half-maximal inhibitory concentration: 5000 nM
Compound 3: the middle estimate sits 25-fold (1.40 log units) below what was measured; the whole stated range lies below it.
By their numbers in this assay, from the lowest: compound 2; then compound 1; then compound 3.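

In this assay, for the compounds shown here, the change to (4-fluorophenyl)amino on the sulfonyl sulfur gives a 50-fold higher number from compound 2 to compound 3 (1.70 log units; beyond the scatter), so this position is not merely responsive to what it carries: a change there can cost far more than the earlier compounds showed. Compound 3 also compares poorly with the benzyl compound, with a 5.0-fold higher number from compound 1 to compound 3 (0.70 log units; beyond the scatter), which places the group with the added hydrogen-bond donor at the high end of the three numbers, beyond the scatter of both others. Nothing at hand about these compounds accounts for the size of these steps.

The step from compound 2 to compound 3 exchanges chlorine for fluorine and adds the amino link in one move, so the compounds shown do not tell which of the two carries the change; 4-fluorophenyl directly on the sulfur, or (4-chlorophenyl)amino in the same place, would separate them. Also open, as far as these compounds go, is whether a methyl group on that amino nitrogen, or an unsubstituted amine on the sulfonyl sulfur, would give a number closer to that of compound 2 or compound 3.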